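This account rests on a few compounds, and the source may have more. Where it says the series, first, only, none or still open, it means among the compounds named here.

Measured so far:
compound 1 `CC(C)(CO)S(=O)(=O)c1cccc(NC(=O)c2cccnc2N2CCC3(CC2)CC3)c1` — > 399 mL.min-1.g-1
compound 2 `COc1ccc(C(=O)Nc2cccc(S(=O)(=O)C3CCCC3)n2)c(N2CCC3(CC2)CC3)c1` — > 399 mL.min-1.g-1

Both values come from an ADME assay on microsomes from liver (Mus musculus) for metabolic stability, read by LC-MS, with a stated time of 40 min, tested at 0.5 uM; a lower number here means slower removal, a higher number faster removal of the compound. For compound 1 the reading > 399 mL.min-1.g-1 is a limit of this assay, not a number. For compound 2 the reading > 399 mL.min-1.g-1 is likewise a limit. Compound 1 thus stands at the edge of what this assay resolves, as does compound 2, so no ordering between them is possible; (the limit of > 399 mL.min-1.g-1 in this assay, at which 2 of the 2 values shown sit).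

Compound 3 `O=C(Nc1cccc(S(=O)(=O)NC2CC2)c1)c1cccnc1N1CCC2(CC1)CC2` is not yet measured. It differs from compound 1 in one place: cyclopropylamino in place of 1-(hydroxymethyl)-1-methylethyl on a sulfonyl sulfur. Among the measured compounds shown here, no measured pair in the set spans such a change, so the step it will produce is not known from data. Given that both measured compounds sit at the limit, the expected step of an at least 1.3-fold lower number from compound 1 to compound 3 (0.12 log units; that floor lies within the scatter) is small, if any, and most likely downward, since no room exists upward. For compound 3 a value near 300 mL.min-1.g-1 is estimated, within a range from 120 mL.min-1.g-1 to 500 mL.min-1.g-1.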

Compound 3, intrinsic clearance in microsomes: > 399 mL.min-1.g-1
Compound 3 ended at the assay's limit; the forecaster's own chance of this, stated with the estimate: 45%; middle value at least 1.3-fold (0.12 log units) away from the limit.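

In this assay compound 3 gives > 399 mL.min-1.g-1, a limit and not a number. No step from compound 1 to compound 3 can be read, as both stand at the same limit: the limit of > 399 mL.min-1.g-1 in this assay, at which 3 of the 3 values shown sit.

The compounds shown leave open how cyclopropylamino and 1-(hydroxymethyl)-1-methylethyl on the sulfonyl sulfur compare in this read-out.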